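The source may hold more compounds than are shown below. What is called first, only, known or untested is meant among the compounds shown, and "the series" means these compounds.

Measured so far in an ADME assay on HepG2 2.2.15 cells (Homo sapiens) for cytotoxicity; on this read-out lower numbers stand for higher toxicity in this test and higher numbers for lower toxicity in this test: compound 1 `Cn1c(=O)c(CCO)c(-c2ccccc2Cl)c2cc(Cl)ccc21` gives 34000 nM. Compound 3 `N#CCC(=O)OCCc1c(-c2ccccc2Cl)c2cc(Cl)ccc2[nH]c1=O` gives 100000 nM. Compound 2 `O=c1c(CCO)c(-c2ccccc2Cl)c2cc(Cl)ccc2n1-c1c(F)cccc1F` does not give a number in this assay but only a limit, > 2300000 nM.

On the numbers shown, compound 3 holds the higher of the two numbers and compound 1 the lower, with a gap between them that lies beyond the scatter. The third value is a limit of the assay, (the limit of > 2300000 nM in this assay, at which 1 of the 3 values shown sits).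

Compound 4 `O=C(CN1C(=O)c2ccccc2C1=O)OCCc1c(-c2ccccc2Cl)c2cc(Cl)ccc2[nH]c1=O` is not yet measured. It differs from compound 3 in one place: a group of 11 heavy atoms (8 carbon, 1 nitrogen, 2 oxygen; one five-membered non-aromatic ring with 1 hetero atom, one six-membered aromatic ring of carbon only) in place of a group of 2 heavy atoms (1 carbon, 1 nitrogen; no ring), on a saturated chain carbon bound to a carbonyl carbon.

Within the data shown here, the only measured step, an at least 67-fold higher number from compound 1 to compound 2 (1.83 log units; beyond the scatter), concerns a substituent on the aromatic nitrogen of the shared core, not the chain carbon bound to a carbonyl carbon where compound 4 changes. Among the measured compounds shown here, no measured step touches the ester side chain, so the step from compound 3 to compound 4 has no direct precedent here. The expectation is therefore a modest move at most, estimated as a 1.5-fold higher number from compound 3 to compound 4 (0.18 log units; within the scatter), with the uncertainty wide on both sides.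

Compound 4 is expected to give about 150000 nM in this assay, with a range from 40000 nM to 600000 nM.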

Compound 4, half-maximal cytotoxic concentration: 960000 nM
Compound 4: the middle estimate sits 6.4-fold (0.81 log units) below what was measured; the measured number lies above the stated range.
By their numbers in this assay, from the lowest: compound 1; then compound 3; then compound 4. At a limit, above all of these: compound 2.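

The ester side chain proves to be a second place on the shared core where a single change moves the read-out in this assay: exchanging cyano for the group of 11 heavy atoms on a saturated chain carbon bound to a carbonyl carbon gives a 9.6-fold higher number from compound 3 to compound 4 (0.98 log units; beyond the scatter). Among these compounds, the only earlier step, an at least 67-fold higher number from compound 1 to compound 2 (1.83 log units; beyond the scatter), concerned a substituent on the aromatic nitrogen, so it said nothing about this chain carbon, and the new step shows that a much larger group carrying two rings is accompanied here by a higher number, meaning lower toxicity in this test, rather than a lower one. No measurement shown here accounts for the size or the direction of this step.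

What stays open is whether the higher number goes with the loss of cyano or with the entering group and its two rings, as the compounds shown include no amine, carboxylic acid or simple phenyl on this chain carbon to tell these apart. As far as these compounds go, it is also open how these esters would read with a methyl or a 2,6-difluorophenyl on the aromatic nitrogen.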